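Three Weak Inhibitors and an Unmeasured Fourth

This account rests on a few compounds, and the source may have more. Where it says the series, first, only, none or still open, it means among the compounds named here.

compound 1 `COc1ccc(C(=O)/C=C/c2ccc(-c3ccccc3)cc2)c2c1C=CC(C)(C)O2`: > 10000 nM
compound 2 `COc1ccc(C(=O)/C=C/c2cccc([N+](=O)[O-])c2)c2c1C=CC(C)(C)O2`: 9720 nM
compound 3 `COc1ccc(C(=O)/C=C/c2ccc(OC)c(OC)c2OC)c2c1C=CC(C)(C)O2`: > 10000 nM

In a functional assay on SK-OV-3 cells (Homo sapiens) for antiproliferative activity, read by MTT assay, with a stated time of 24 h (a higher number here means a weaker inhibitor, a lower number a stronger inhibitor), compound 1 gives only a limit, > 10000 nM. Compound 3 likewise gives only a limit in this assay, > 10000 nM. Going by the values given here, compound 2 gives the sole number among the three, 9720 nM, standing just inside the measured range. Among the compounds with values here, the edge of that range is the limit of > 10000 nM in this assay, at which 2 of the 3 values shown sit, and no step between two measured compounds can be drawn. Compound 4 `COc1ccc(C(=O)/C=C/c2ccc(O)c(Br)c2)c2c1C=CC(C)(C)O2` differs from compound 2 by 3-bromo-4-hydroxyphenyl in place of 3-nitrophenyl on a double-bonded chain carbon bound to a double-bonded chain carbon. Within the data shown here, with no measured step to guide it, the account expects in this assay a step of a 1.2-fold lower number from compound 2 to compound 4 (0.08 log units; within the scatter), not beyond the scatter. Compound 4 is therefore expected to give 8000 nM, within 2000 nM to 20000 nM.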

Compound 4, half-maximal inhibitory concentration: > 10000 nM
Compound 4 ended at the assay's limit; the forecaster's own chance of this, stated with the estimate: 40%; middle value at least 1.2-fold (0.09 log units) from the limit.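

In this assay compound 4 gives > 10000 nM, which is a limit of the assay and not a number. Putting 3-bromo-4-hydroxyphenyl in place of 3-nitrophenyl on a double-bonded chain carbon bound to a double-bonded chain carbon gives an at least 1.0-fold higher number from compound 2 to compound 4 (0.01 log units; that floor lies within the scatter), so this change brings no lower number, and how far the step runs cannot be read. The hydroxyl-bearing ring thus joins the other groups at this position at the assay's edge: the limit of > 10000 nM in this assay, at which 3 of the 4 values shown sit.

As far as these compounds go, whether an amine or a carboxylic acid on this ring would bring a number well inside the limit remains open. From the compounds shown here alone, how far compound 1, compound 3 and compound 4 lie past that limit also remains open.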